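The compounds below may be only part of what the source reports. "The series", "measured", "known", "first", "only" and "open" are said of these compounds alone.

Working notes on the series. Compound 1 `CC(C)Cc1ccc(C(C)c2nnc3n2N=C(c2ccc(F)cc2)CS3)cc1` and compound 2 `CC(C)Cc1ccc(C(C)c2nnc3n2N=C(c2ccccc2)CS3)cc1` share the core and differ by hydrogen in place of fluoro on an aromatic carbon. In a functional assay on Huh-7 cells (Homo sapiens) for inhibition, read by sulforhodamine B assay, with a stated time of 72 h (on this read-out higher numbers stand for weaker inhibition and lower numbers for stronger inhibition), compound 1 gives 7800 nM and compound 2 gives 6100 nM; the step of a 1.3-fold lower number from compound 1 to compound 2 (0.11 log units; within the scatter) is within the scatter. Compound 3 `CC(C)Cc1ccc(C(C)c2nnc3n2N=C(c2ccc([N+](=O)[O-])cc2)CS3)cc1` gives "not active" (no number reported) in this assay, so no number places compound 3 against the other two; it stands apart only as the member for which no value was returned. Compound 4 `CC(C)Cc1ccc(C(C)c2nnc3n2N=C(c2ccc(Cl)cc2Cl)CS3)cc1` differs from compound 3 by 2,4-dichlorophenyl in place of 4-nitrophenyl on a carbon with a double bond to nitrogen. Among the compounds with values here, no measured step covers this change directly. Within the data shown here, the one measured step, a 1.3-fold lower number from compound 1 to compound 2 (0.11 log units; within the scatter), concerns fluoro against hydrogen and lies within the scatter, so it sets no direction for a dichloro substitution. What the numbers show is that compound 1 and compound 2 both return values of the same order while compound 3 returns none. Compound 4 is expected to fall closer to the range seen for compound 1 and compound 2 than to repeat the outcome of compound 3. The estimate for compound 4 in this assay is 8000 nM, with a range from 2500 nM to 30000 nM.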

Compound 4, half-maximal inhibitory concentration: 7500 nM
Compound 4: the middle estimate sits 1.1-fold (0.03 log units) above what was measured, within the range that was stated.
By their numbers in this assay, from the lowest: compounds 2, 4 and 1 (each within the scatter of the next).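

In this assay, the steps of a 1.2-fold higher number from compound 2 to compound 4 (0.09 log units; within the scatter) and a 1.0-fold lower number from compound 1 to compound 4 (0.02 log units; within the scatter) both lie within the scatter, so phenyl, 4-fluorophenyl and 2,4-dichlorophenyl on the carbon with a double bond to nitrogen cannot be told apart on this read-out. This position therefore accepts a group with two chlorine atoms and still returns a number of the same order, whereas the 4-nitrophenyl of compound 3 returned none, and the step between compound 3 and compound 4 cannot be read. Nothing at hand accounts for that difference in outcome.

Open, as far as these compounds go, is how a 4-aminophenyl or a 4-carboxyphenyl group would read at this position, and so whether the outcome of compound 3 belongs to 4-nitrophenyl alone. Also open, from the compounds shown here alone, is what a change elsewhere on the shared core would do, since all four compounds keep it unchanged.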